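This account rests on a few compounds, and the source may have more. Where it says the series, first, only, none or still open, it means among the compounds named here.

Measured in a functional assay on the whole organism (blood, strain albino) with Mus musculus as the target, with stated times of 6 days and 4 h, at a dose of 1 mmol/kg by the oral route; on this read-out higher numbers stand for more inhibition at the one dose given (going by the name of the read-out) and lower numbers for less inhibition:

compound 1 `Cc1cc(C)n(-c2ccc(S(=O)(=O)N3CC(=O)N(Cc4ccccc4)C3=S)cc2)n1` — 1%
compound 2 `Cc1cc(C)n(-c2ccc(S(=O)(=O)N3CC(=O)N(C4CCCCC4)C3=S)cc2)n1` — 2%
compound 3 `CCCCN1C(=O)CN(S(=O)(=O)c2ccc(-n3nc(C)cc3C)cc2)C1=S` — 1%

Compound 2 gives the largest of the three numbers, but its steps to the other two are within the scatter: a number 1 percentage points higher from compound 1 to compound 2 (within the scatter) and a number 1 percentage points lower from compound 2 to compound 3 (within the scatter); likewise no change at the digits printed from compound 1 to compound 3 (within the scatter). All three steps change only the group on the amide-type nitrogen in the ring, and none of them moves the read-out.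

Compound 4 `Cc1cc(C(=O)O)nn1-c1ccc(S(=O)(=O)N2CC(=O)N(C3CCCCC3)C2=S)cc1` differs from compound 2 by carboxy in place of methyl on an aromatic carbon. Among the measured compounds shown here, no measured step touches the five-membered aromatic ring with 2 nitrogen, so the measured compounds say nothing directly about this change. What they do show is that the three numbers sit together at the low end of the scale at this dose. Compound 4 is therefore expected to stay at that level, with a number 1 percentage points higher from compound 2 to compound 4 (within the scatter) expected to be no step beyond the scatter. The estimate for compound 4 in this assay is 3%, with a range from 0% to 12%.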

Compound 4, a percentage reported as inhibition, in the whole organism at one dose (the size of the read-out at that dose, not a potency): 1%
Compound 4: middle estimate off by 2 percentage points, on the high side, and the stated range covers the measured number.
By their numbers in this assay, from the lowest: compounds 1, 3, 4 and 2 (each within the scatter of the next).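

Among the compounds shown here, the one measured change on the five-membered aromatic ring with 2 nitrogen, 3,5-dimethyl-1H-pyrazol-1-yl to 3-carboxy-5-methyl-1H-pyrazol-1-yl, gives in this assay a number 1 percentage points lower from compound 2 to compound 4 (within the scatter). This aromatic carbon therefore joins the amide-type nitrogen as a place where a change leaves the number at the low end of the scale, even with a hydrogen-bond donor and a hydrogen-bond acceptor entering with the carboxy group. No evidence is available on what lies behind this result.

Open, going by these compounds, is whether an amine, an ester or a primary amide on this aromatic carbon would lift the read-out out of the low range. Also open, on these data alone, is whether carboxy behaves the same with benzyl or butyl on the amide-type nitrogen as it does with cyclohexyl.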